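Pentafluoroethyl for pentafluorosulfanyl on a second anilide

This account rests on a few compounds, and the source may have more. Where it says the series, first, only, none or still open, it means among the compounds named here.

The study compares four compounds that share a hydroxy-amide core bearing an aryl ether on one side and an anilide on the other. Compound 1 `CC(O)(COc1cccc(S(F)(F)(F)(F)F)c1)C(=O)Nc1ccc(C(F)(F)F)cc1` carries a pentafluorosulfanyl group on the ether ring and a single trifluoromethyl group on the anilide ring. In a functional assay on VCaP cells (Homo sapiens) for antiproliferative activity, read by propidium iodide staining, with a stated time of 96 h (on this read-out higher numbers stand for weaker inhibition and lower numbers for stronger inhibition), compound 1 gives 23800 nM. Compound 3 `CC(O)(COc1cccc(C(F)(F)C(F)(F)F)c1)C(=O)Nc1ccc(C(F)(F)F)cc1` differs from compound 1 by a group of 7 heavy atoms (2 carbon, 5 fluorine; no ring) in place of a group of 6 heavy atoms (5 fluorine, 1 sulfur; no ring), on an aromatic carbon. In this assay compound 3 gives 8100 nM, which is a 2.9-fold lower number from compound 1 to compound 3 (0.47 log units; beyond the scatter).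

Compound 2 `CC(O)(COc1cccc(S(F)(F)(F)(F)F)c1)C(=O)Nc1cc(C(F)(F)F)cc(C(F)(F)F)c1` keeps the pentafluorosulfanyl ether but carries two trifluoromethyl groups on the anilide ring; the difference between its core and that of compound 1 is not broken down here. In this assay compound 2 gives 2700 nM, the lowest of the three numbers, with compound 3 nearest and compound 1 furthest.

Compound 4 `CC(O)(COc1cccc(C(F)(F)C(F)(F)F)c1)C(=O)Nc1cc(C(F)(F)F)cc(C(F)(F)F)c1` has not been measured. It differs from compound 2 by a group of 7 heavy atoms (2 carbon, 5 fluorine; no ring) in place of a group of 6 heavy atoms (5 fluorine, 1 sulfur; no ring), on an aromatic carbon, the same change seen from compound 1 to compound 3, at a place described in the same words. Since that earlier step was a 2.9-fold lower number from compound 1 to compound 3 (0.47 log units; beyond the scatter), the account expects a step of similar size on the other anilide, estimated as a 2.8-fold lower number from compound 2 to compound 4 (0.45 log units; beyond the scatter). Compound 4 is therefore expected to give about 950 nM in this assay, with a plausible range from 400 nM to 2500 nM.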

Compound 4, half-maximal inhibitory concentration: 9500 nM
Beside the measured number, compound 4's estimate is 10-fold (1.00 log units) below it, outside the stated range (above it).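

On the anilide with two trifluoromethyl groups, 1,1,2,2,2-pentafluoroethyl in place of pentafluorosulfanyl gives a 3.5-fold higher number from compound 2 to compound 4 (0.55 log units; beyond the scatter) in this assay, so the step runs in the opposite direction to the one seen on the core of compound 1. Set side by side, the two steps disagree in direction and lie further apart than the scatter of two such steps allows: the same change on two cores in this assay, a 2.9-fold lower number (0.47 log units; beyond the scatter) from compound 1 to compound 3 and a 3.5-fold higher number (0.55 log units; beyond the scatter) from compound 2 to compound 4, 10-fold (1.01 log units) apart, beyond the scatter of two such steps. Within the data shown here, this shows that, across these two pairs, the effect of the exchange does not carry from one anilide to the other, so a step read on one core is a poor guide to the same step on the other; it does not show why the direction reverses, or which of the two steps would be the more typical on a further anilide, since each core supplies only a single pair.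

The compounds shown leave open how other groups on the ether ring, such as trifluoromethyl, chlorine or a nitrile, would behave on these two anilides. From the compounds shown here alone, it also remains open whether the reversal would persist on an anilide bearing a nitrile or a chlorine atom in place of a trifluoromethyl group.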